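Swapping chloro for methyl on the distal aryl ring

A few compounds are considered here, and "the series" means these few. Any claim that something is new, unique, unknown or untested is made for them only; others in the source may bear on it.

Compound 2 `Cc1cc(-c2cccc(Cl)c2)cc(C)c1Nc1ccnc(Nc2ccc(C#N)cc2)n1` gives 2160 nM in an ADME assay on MT4 cells (Homo sapiens) for cytotoxicity, read by MTT assay, with a stated time of 4 days (on this read-out lower numbers stand for higher toxicity in this test and higher numbers for lower toxicity in this test), and compound 1 `Cc1cc(-c2cccc(C(F)(F)F)c2)cc(C)c1Nc1ccnc(Nc2ccc(C#N)cc2)n1` gives 4030 nM, the two standing within the usual scatter of each other; the step of a 1.9-fold lower number from compound 1 to compound 2 (0.27 log units; within the scatter) is the only one measured. Compound 3 `Cc1ccc(-c2cc(C)c(Nc3ccnc(Nc4ccc(C#N)cc4)n3)c(C)c2)cc1` differs from compound 2 by 4-methylphenyl in place of 3-chlorophenyl on an aromatic carbon. Among the compounds with values here, no measured step matches this change, and the one known step is small, so no step beyond the scatter is expected. Compound 3 is therefore expected to give 2500 nM, between 900 nM and 7000 nM, an expected step of a 1.2-fold higher number from compound 2 to compound 3 (0.06 log units; within the scatter).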

Compound 3, half-maximal cytotoxic concentration: 5570 nM
Compound 3: the middle estimate sits 2.2-fold (0.35 log units) below what was measured; the range from low to high includes it.
By their numbers in this assay, from the lowest: compounds 2, 1 and 3 (each within the scatter of the next, the first and the last beyond it).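

In this assay this position now gives a step beyond the scatter, with 4-methylphenyl in place of 3-chlorophenyl giving a 2.6-fold higher number from compound 2 to compound 3 (0.41 log units; beyond the scatter) where the earlier pair stayed within it. With 4-methylphenyl in place of 3-(trifluoromethyl)phenyl the record reads a 1.4-fold higher number from compound 1 to compound 3 (0.14 log units; within the scatter) and remains within the scatter, so replacing the ring here does not always carry a step beyond it. No measurement at hand bears on why the numbers fall this way.

Going by these compounds, the change alters both the substituent and its place on the ring, and which of the two counts stays open. On these data alone, how a phenyl bearing an amine or a carboxylic acid would read here also stays open.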